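The compounds below may be only part of what the source reports. "The series", "measured", "known", "first", "only" and "open" are said of these compounds alone.

In a physicochemical assay for lipophilicity (a higher number here means a more lipophilic compound, a lower number a more polar compound), compound 1 `CC(C)(C)C#Cc1cc(N(C(=O)[C@H]2CC[C@H](C)CC2)[C@H]2CC[C@H](Oc3ccc4nccn4n3)CC2)c(C(=O)O)s1` gives 2.4, level with compound 3 `CC(C)(C)C#Cc1cc(N(C(=O)[C@H]2CC[C@H](C)CC2)[C@H]2CC[C@H](OC3CCOC3)CC2)c(C(=O)O)s1` at 2.3, while compound 2 `CC(C)(C)C#Cc1cc(N(C(=O)[C@H]2CC[C@H](C)CC2)[C@H]2CC[C@@H](Oc3ccc(=O)[nH]n3)CC2)c(C(=O)O)s1` gives 1.8, which falls short of compound 1 by more than the scatter. Compound 4 `CC(C)(C)C#Cc1cc(N(C(=O)[C@H]2CC[C@H](C)CC2)[C@H]2CC[C@H](Oc3ccc(=O)[nH]n3)CC2)c(C(=O)O)s1` alters the group on the oxygen: a group of 7 heavy atoms (4 carbon, 2 nitrogen, 1 oxygen; one six-membered aromatic ring with 2 hetero atoms) in place of a group of 9 heavy atoms (6 carbon, 3 nitrogen; one five-membered aromatic ring with 2 hetero atoms, one six-membered aromatic ring with 2 hetero atoms), on an oxygen on a saturated carbon. Going by the values given here, one measured step bears on this: a number 0.10 log units lower from compound 1 to compound 3 (within the scatter), where a different group replaced the same departing one. That step says little about the incoming group. Compound 4 shares that group with compound 2, differing only in the spatial arrangement at the saturated carbon holding the oxygen, and compound 2 reads 1.8. The expected step in this assay is therefore a number 0.50 log units lower from compound 1 to compound 4 (beyond the scatter), a fall beyond the scatter. For compound 4 the estimate is 1.9, with an expected range from 1.5 to 2.3.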

Compound 4, distribution coefficient: 2
Compound 4: the middle estimate sits 0.10 log units below what was measured; the measured number falls inside the stated range.
By their numbers in this assay, from the lowest: compounds 2, 4, 3 and 1 (each within the scatter of the next, the first and the last beyond it).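

In this assay, the group with one six-membered aromatic ring on this oxygen now has a direct comparison with the two-ring group it replaces: a number 0.40 log units lower from compound 1 to compound 4 (beyond the scatter). Against the five-membered non-aromatic ring, the same group gives a number 0.30 log units lower from compound 3 to compound 4 (within the scatter). Reversing the spatial arrangement leaves the reading within the scatter, a number 0.20 log units higher from compound 2 to compound 4 (within the scatter), so this pair shows no clear effect of arrangement, as the comparison is clean: the fact that compounds 2 and 4 differ only in the configuration as drawn

Going by these compounds, whether a methyl group or a chain ending in an amine on this oxygen would read lower remains open. So does whether spatial arrangement matters as little with other groups.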